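Three Measured Compounds and One Expected: Compound 4

The source may hold more compounds than are shown below. What is called first, only, known or untested is meant among the compounds shown, and "the series" means these compounds.

Compound 1 `CC(=O)Oc1ccc(C(=O)Nc2cc3ccc(OCC4CCN(C)C4)c(C)c3oc2=O)cc1CC=C(C)C`: 1880 nM
Compound 2 `CC(=O)Oc1ccc(C(=O)Nc2cc3ccc(OCC4CCCNC4)c(C)c3oc2=O)cc1CC=C(C)C`: 820 nM
Compound 3 `CC(C)=CCc1cc(C(=O)Nc2cc3ccc(OCC4CCN(C)C4)c(C)c3oc2=O)ccc1O`: 1550 nM

In a functional assay on MCF7 cells (Homo sapiens) for antiproliferative activity (a lower number here means a stronger inhibitor, a higher number a weaker inhibitor), compound 3 stands second highest of the three numbers; its gap to compound 1 and its gap to compound 2 both lie within the scatter. Compound 4 `CC(C)=CCc1cc(C(=O)Nc2cc3ccc(OCCCN(C)C(C)(C)C)c(C)c3oc2=O)ccc1O` differs from compound 3 in one place: 2-(methyl(tert-butyl)amino)ethyl in place of 1-methylpyrrolidin-3-yl on a saturated chain carbon bound to an oxygen on an aromatic ring. Among the compounds with values here, the only measured step touching the amine is a 2.3-fold lower number from compound 1 to compound 2 (0.36 log units; beyond the scatter), a modest shift; the step of a 1.2-fold lower number from compound 1 to compound 3 (0.08 log units; within the scatter) concerns the acetyl and stays within the scatter. Within the data shown here, no measured pair covers a ring-to-chain exchange, so the data give little direction. Compound 4 is therefore expected to stay close to compound 3, with an estimated 1300 nM in this assay, between 450 nM and 3800 nM. The expected step is a 1.2-fold lower number from compound 3 to compound 4 (0.08 log units; within the scatter).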

Compound 4, half-maximal inhibitory concentration: 1140 nM
Compound 4: the middle estimate sits 1.1-fold (0.06 log units) above what was measured, within the range that was stated.
By their numbers in this assay, from the lowest: compounds 2, 4, 3 and 1 (each within the scatter of the next, the first and the last beyond it).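

In this assay, the exchange of the ring-bearing 1-methylpyrrolidin-3-yl for the open-chain 2-(methyl(tert-butyl)amino)ethyl gives a 1.4-fold lower number from compound 3 to compound 4 (0.13 log units; within the scatter). This position therefore accepts an amine with no ring and a larger group, with no shift that can be told from the scatter. Nothing measured here speaks to why the number holds.

Still open, on these data alone, is whether a carboxylic acid or a morpholine in place of the amine would be accepted at this position. As far as these compounds go, it is also open whether the same exchange would read alike with the acetyl on the oxygen on the aromatic ring.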